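Aryl swap on the five-membered ring of the shared core

The source may report more compounds than this note shows. Statements on the series, on what has been measured and on what is new or still open speak of the compounds shown alone.

Compound 1 `O=C1C[C@H](OCc2cc(-c3ccc([N+](=O)[O-])cc3)no2)[C@H]2CO[C@@H]1O2` and compound 2 `O=C1C[C@H](OCc2cc(/C=C/c3ccccc3)no2)[C@H]2CO[C@@H]1O2` share one core and differ only in the group carried on the five-membered aromatic ring. In a functional assay on HT-29 cells (Homo sapiens) for cytotoxicity, read by MTT assay, with a stated time of 48 h (on this read-out higher numbers stand for weaker inhibition and lower numbers for stronger inhibition), compound 1 gives 19800 nM, and in this assay compound 2 gives 13700 nM; the two numbers sit within the scatter of each other, so neither stands apart. Compound 3 `O=C1C[C@H](OCc2cc(-c3ccc(Cl)cc3)no2)[C@H]2CO[C@@H]1O2` carries 4-chlorophenyl in place of 2-phenylethenyl on an aromatic carbon. Among the compounds with values here, no measured pair shows this change, so the expected step of a 1.2-fold higher number from compound 2 to compound 3 (0.07 log units; within the scatter) is none beyond the scatter. Compound 3 is expected to give 16000 nM, with a range from 7000 nM to 40000 nM.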

Compound 3, half-maximal inhibitory concentration: 14500 nM
Compound 3: the middle estimate sits 1.1-fold (0.04 log units) above what was measured; measured number inside the range.
By their numbers in this assay, from the lowest: compounds 2, 3 and 1 (each within the scatter of the next).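

Two more swaps now read at this position, the aromatic carbon next to the ring nitrogen. In this assay, 4-chlorophenyl in place of 2-phenylethenyl gives a 1.1-fold higher number from compound 2 to compound 3 (0.02 log units; within the scatter), and chloro in place of nitro gives a 1.4-fold lower number from compound 1 to compound 3 (0.14 log units; within the scatter), so neither change separates the compounds. No measured evidence bears on these results.

Open, from the compounds shown here alone, is whether any group here moves the number beyond the scatter. An amine or a carboxylic acid in place of chloro, or a saturated alkyl chain in place of 4-chlorophenyl, could test this.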